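Methoxy step transferred to a second core

The source may report more compounds than this note shows. Statements on the series, on what has been measured and on what is new or still open speak of the compounds shown alone.

Compound 1 `c1ccc(-c2nc3cccnc3o2)cc1` gives 55% in a functional assay on the whole organism for inhibition, with Rattus norvegicus as the target, at a dose of 30 mg/kg; on this read-out lower numbers stand for less inhibition and higher numbers for more inhibition at the one dose given (going by the name of the read-out).
Compound 2 `COc1cccc(-c2nc3cccnc3o2)c1` gives 0% in this assay.
Compound 3 `N#Cc1ccccc1-c1nc2ncccc2o1` gives 62% in this assay.

Compound 2 differs from compound 1 by methoxy in place of hydrogen on an aromatic carbon, and that step made a number 55 percentage points lower from compound 1 to compound 2 (beyond the scatter). Compound 4 `COc1ccc(C#N)c(-c2nc3ncccc3o2)c1` is not yet measured; it differs from compound 3 by methoxy in place of hydrogen on an aromatic carbon. This is the same kind of change, not the same one: here the place is also para to a cyano group. How the core of compound 1 and the core of compound 3 differ is not broken down here. Compound 3 and compound 1 lie within the scatter of each other; compound 3 and compound 2 lie beyond it. A large downward step is expected from compound 3 to compound 4, a number 50 percentage points lower from compound 3 to compound 4 (beyond the scatter), because the earlier methoxy step gave a number 55 percentage points lower from compound 1 to compound 2 (beyond the scatter). Compound 4 is estimated at 12%, expected between 0% and 40%.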

Compound 4, a percentage reported as inhibition, in the whole organism at one dose (the size of the read-out at that dose, not a potency): 3%
Beside the measured number, compound 4's estimate is 9 percentage points above it; measured number inside the range.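

Methoxy in place of hydrogen on an aromatic carbon carries over to the second core in this assay, giving a number 59 percentage points lower from compound 3 to compound 4 (beyond the scatter). The two steps agree in size across the cores: the same change on two cores in this assay, a number 55 percentage points lower (beyond the scatter) from compound 1 to compound 2 and a number 59 percentage points lower (beyond the scatter) from compound 3 to compound 4, 4 percentage points apart, within the scatter of two such steps. This rests on a single pair for each core, and in compound 4 the methoxy also sits para to a cyano group; the result does not show how the change behaves on any other core, nor does it separate the methoxy from that placement.

The compounds shown leave open whether the drop is specific to methoxy or also follows from other groups, such as an amine, a carboxylic acid or a longer alkoxy chain. Going by these compounds, whether methoxy elsewhere on the carbon ring gives a similar step also remains open.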